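A 4-hydroxy-3-methoxyphenyl group replaces a 3-nitrophenyl group

The source may hold more compounds than are shown below. What is called first, only, known or untested is meant among the compounds shown, and "the series" means these compounds.

Compound 1 `COc1ccc(/C=C2\CCC/C(=C\c3cccc([N+](=O)[O-])c3)C2=O)cc1` gives 44.7 ug/mL
Compound 2 `O=C1/C(=C/c2ccc([N+](=O)[O-])cc2)CCC/C1=C\c1cccc([N+](=O)[O-])c1` gives 8.85 ug/mL
Compound 3 `O=C1/C(=C/c2cccc(Cl)c2)CCC/C1=C\c1cccc([N+](=O)[O-])c1` gives 5.01 ug/mL

These values come from a functional assay on MDA-MB-231 cells (Homo sapiens) for cytotoxicity, read by MTT assay (a higher number here means a weaker inhibitor, a lower number a stronger inhibitor), and are the starting point for judging one unmeasured compound. Compound 2 sits at the low end of these numbers together with its nearest neighbour, and the gap there is a 1.8-fold lower number from compound 2 to compound 3 (0.25 log units; within the scatter) and so no real difference. Its other neighbour lies much further off, with a 5.1-fold lower number from compound 1 to compound 2 (0.70 log units; beyond the scatter) as a step that does count.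

The next compound, compound 4 `COc1cc(/C=C2\CCC/C(=C\c3ccc([N+](=O)[O-])cc3)C2=O)ccc1O`, has no value yet. Its difference from compound 2 is 4-hydroxy-3-methoxyphenyl in place of 3-nitrophenyl on a double-bonded chain carbon bound to a double-bonded ring carbon and the rest of the structure stays the same.

The best guide is a 5.1-fold lower number from compound 1 to compound 2 (0.70 log units; beyond the scatter) where nitro takes the place of methoxy on an aromatic carbon. Read backwards, this suggests that a methoxy-bearing ring raises the number. The step of an 8.9-fold lower number from compound 1 to compound 3 (0.95 log units; beyond the scatter) points the same way. Going by the values given here, neither is an exact match, and no measured compound carries the hydroxy group, so the size remains uncertain.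

The expected change is a 2.3-fold higher number from compound 2 to compound 4 (0.35 log units; beyond the scatter) and this is a rise somewhat smaller than those guiding steps suggest. The estimate for compound 4 is 20 ug/mL (expected range 6 ug/mL to 60 ug/mL).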

Compound 4, half-maximal inhibitory concentration: 13.1 ug/mL
Beside the measured number, compound 4's estimate is 1.5-fold (0.18 log units) above it; the range from low to high includes it.
By their numbers in this assay, from the lowest: compounds 3, 2 and 4 (each within the scatter of the next, the first and the last beyond it); then compound 1.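

In this assay, going by these compounds alone, the step of a 1.5-fold higher number from compound 2 to compound 4 (0.17 log units; within the scatter) is the first to touch the 3-nitrophenyl group, which compounds 1, 2 and 3 all keep while only their other substituted phenyl group varies. It shows that, with 4-nitrophenyl kept in the molecule, 4-hydroxy-3-methoxyphenyl can take the place of 3-nitrophenyl with no real shift in the number, so a nitro group on this phenyl ring is not needed to hold it there. A methoxy-bearing ring therefore does not always bring the weaker result seen in the step of a 5.1-fold lower number from compound 1 to compound 2 (0.70 log units; beyond the scatter), and compound 1 stays the one case of that penalty, on a different group of the molecule and with a simple 4-methoxyphenyl.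

Nothing measured here offers a reason for this tolerance. Hydroxy and methoxy enter together, so their separate shares stay open, as does how an amine or a carboxylic acid on this ring would read, or whether the result holds with a partner other than 4-nitrophenyl.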